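Swapping the amide ring partner in a metabotropic glutamate receptor 5 series

The source may hold more compounds than are shown below. What is called first, only, known or untested is meant among the compounds shown, and "the series" means these compounds.

Measured so far:
Compound 1, `O=C(C1CCC(F)(F)CC1)N1CC(c2nc(-c3cccc(Cl)c3)no2)C1`: 180 nM
Compound 2, `O=C(c1ccc(F)cc1)N1CC(c2nc(-c3cccc(F)c3)no2)C1`: 2400 nM

Both compounds were tested in an assay on HEK293 cells for positive allosteric modulation of metabotropic glutamate receptor 5 (Homo sapiens), read by FLIPR; on this read-out higher numbers stand for an effect only at larger amounts of compound and lower numbers for an effect already at smaller amounts. Compound 1 gives 180 nM and holds the lower of the two numbers; compound 2 gives 2400 nM, and the gap between them lies beyond the usual scatter. The two compounds differ in more than one place, so no single change can be tied to that gap.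

Compound 3, `O=C(C1CCCO1)N1CC(c2nc(-c3cccc(Cl)c3)no2)C1`, has not yet been measured. It differs from compound 1 in a single place: oxolan-2-yl in place of 4,4-difluorocyclohexyl on a carbonyl carbon. The group that leaves is a six-membered carbon ring carrying two fluorines; the group that enters is a smaller five-membered ring with one oxygen, bringing one hydrogen-bond acceptor where none was before.

Among the measured compounds shown here, no measured pair in this set isolates such a change, so the expectation rests on compound 1 alone. The step of a 2.8-fold higher number from compound 1 to compound 3 (0.44 log units; beyond the scatter) is expected to be a modest one toward a higher number, beyond the scatter but well short of the distance to compound 2. Compound 3 is therefore estimated at about 500 nM, with a range from 120 nM to 2500 nM.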

Compound 3, half-maximal effective concentration: > 10000 nM
Compound 3 ended at the assay's limit; the forecaster's own chance of this, stated with the estimate: 5%; middle value at least 20-fold (1.30 log units) away from the limit.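

In this assay compound 3 gives > 10000 nM, which is a limit of the assay and not a number: the limit of > 10000 nM in this assay, at which 1 of the 3 values shown sits. On these data alone, putting oxolan-2-yl in place of 4,4-difluorocyclohexyl on the carbonyl carbon gives an at least 55-fold higher number from compound 1 to compound 3 (1.74 log units; beyond the scatter), so the true distance remains unknown, but this one change is enough to move the result to that limit. The earlier pair could not show this, as compound 1 and compound 2 differ in more than one place, whereas here the group on this carbonyl carbon is the only difference and clearly matters a great deal.

The compounds shown leave open which part of the change counts, as the smaller ring, the loss of the two fluorines and the arrival of the ring oxygen all come together in this one step, and the data give no way to tell them apart. A plain cyclohexyl group on the same carbonyl carbon, keeping the six-membered carbon ring without the fluorines, would begin to separate these parts.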